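A few compounds are considered here, and "the series" means these few. Any claim that something is new, unique, unknown or untested is made for them only; others in the source may bear on it.

Measured compounds in a functional assay on HCT-15 cells (Homo sapiens) for cytotoxicity, read by CCK-8 assay and cell counting, with a stated time of 2 days; a higher number here means a weaker inhibitor, a lower number a stronger inhibitor:
compound 1 `Oc1cccc(-c2cc(-c3ccsc3)nc(-c3ccccc3Cl)c2)c1` gives 2500 nM
compound 2 `Oc1ccc(-c2cc(-c3ccco3)nc(-c3ccccc3Cl)c2)cc1` gives 5460 nM

Compound 2 stands highest of the two numbers in this assay; the nearer number is that of compound 1, which is lower by more than the usual scatter. Compound 1 and compound 2 differ in two places at once, so their gap cannot be assigned to either change alone.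

Compound 3 `Oc1ccc(-c2cc(-c3ccsc3)nc(-c3ccccc3Cl)c2)cc1` is the next compound to be measured in this assay. It differs from compound 2 in one place:
thiophen-3-yl in place of furan-2-yl on an aromatic carbon
This brings into compound 3 the same five-membered group that compound 2 lacks and compound 1 carries, while the hydroxyphenyl group of compound 2 is kept. Among the measured compounds shown here, with no single-change step available, the expected direction rests only on the lower number of compound 1 2500 nM, so a modest fall in the number is expected, of roughly the size a 1.6-fold lower number from compound 2 to compound 3 (0.21 log units; within the scatter), and it may well stay within the scatter. Compound 3 is therefore estimated at 3400 nM in this assay, with a plausible range from 1600 nM to 7500 nM.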

Compound 3, half-maximal inhibitory concentration: 5830 nM
For compound 3 the middle estimate is 1.7-fold (0.23 log units) below the measured one; low and high end bracket the measured number.
By their numbers in this assay, from the lowest: compound 1; then compounds 2 and 3 (each within the scatter of the next).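

In this assay, thiophen-3-yl in place of furan-2-yl, on the aromatic carbon next to the ring nitrogen, gives no separation between the two five-membered rings (a 1.1-fold higher number from compound 2 to compound 3 (0.03 log units; within the scatter)). Among the compounds shown here, with thiophen-3-yl held constant, 4-hydroxyphenyl in place of 3-hydroxyphenyl is the one single change here that exceeds the scatter (a 2.3-fold higher number from compound 1 to compound 3 (0.37 log units; beyond the scatter)), so the placement of the hydroxyl group on that phenyl ring registers in this assay while this heteroaryl swap does not. No measurement available here bears on the reason for either outcome.

From the compounds shown here alone, whether the same hydroxyphenyl step holds with furan-2-yl at the five-membered ring position remains open. Also open is how this position responds to a group outside the two five-membered rings shown, such as an amine, a carboxylic acid or a longer chain.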